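The source may report more compounds than this note shows. Statements on the series, on what has been measured and on what is new or still open speak of the compounds shown alone.

Measured compounds in a functional assay on HT-29 cells (Homo sapiens) for cytotoxicity, read by MTT assay, with a stated time of 72 h; on this read-out higher numbers stand for weaker inhibition and lower numbers for stronger inhibition:

Compound 1, `COC(=O)c1sc2cc(C)ccc2c1Nc1cc(OC)c(OC)c(OC)c1`: 1.9 nM
Compound 2, `COC(=O)c1sc2ncccc2c1Nc1cc(OC)c(OC)c(OC)c1`: 542 nM
Compound 3, `CCOC(=O)c1sc2cc(C)ccc2c1Nc1cc(OC)c(OC)c(OC)c1`: 6 nM

Compound 1 and compound 3 share a core and differ only in the ester: methyl in place of hydrogen on a saturated chain carbon bound to an oxygen next to a carbonyl group. That change gives a 3.2-fold higher number from compound 1 to compound 3 (0.50 log units; beyond the scatter), a step that is modest but lies beyond the usual scatter.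

Compound 2 carries a different core, and the difference between the two cores is not broken down here. It stands with the highest number of the three: compared with compound 3 its number is higher, and compared with compound 1 it is higher still, both gaps well beyond the scatter.

Compound 4, `CCOC(=O)c1sc2ncccc2c1Nc1cc(OC)c(OC)c(OC)c1`, has not been measured in this assay. It is related to compound 2 by methyl in place of hydrogen on a saturated chain carbon bound to an oxygen next to a carbonyl group, which is the same change as from compound 1 to compound 3, at the same place. On that one precedent, the step from compound 2 to compound 4 is expected to be a 3.1-fold higher number from compound 2 to compound 4 (0.50 log units; beyond the scatter), with the same direction and roughly the same size because the only measured case of this change gave a 3.2-fold higher number from compound 1 to compound 3 (0.50 log units; beyond the scatter). Whether the change transfers unaltered onto the core of compound 2 is not tested by any other pair here, so the range around the estimate is kept wide. Compound 4 is thus expected to give about 1700 nM, between 550 nM and 5500 nM.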

Compound 4, half-maximal inhibitory concentration: 2260 nM
Compound 4: middle estimate off by 1.3-fold (0.12 log units), on the low side, within the range that was stated.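

In this assay, the change from methoxycarbonyl to ethoxycarbonyl gives a 4.2-fold higher number from compound 2 to compound 4 (0.62 log units; beyond the scatter), again toward weaker inhibition. Set side by side, the steps on the two cores run in the same direction, and their sizes cannot be told apart: the same change on two cores in this assay, a 3.2-fold higher number (0.50 log units; beyond the scatter) from compound 1 to compound 3 and a 4.2-fold higher number (0.62 log units; beyond the scatter) from compound 2 to compound 4, 1.3-fold (0.12 log units) apart, within the scatter of two such steps. Among the compounds shown here, this shows that, for this one ester pair in this one assay, the step carried from one core to the other even though the two cores stand far apart in their numbers; it does not show that the change would behave the same way on other cores or in other cells, and with only two pairs it gives no explanation of why the number rises.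

Open, going by these compounds, is what happens beyond the ethyl ester, whether with a longer chain such as propyl, a branched chain such as isopropyl, or a carboxylic acid or a primary amide in place of the ester, and whether any such replacement would behave alike on both cores. Also open, on these data alone, is whether the step keeps its direction and size on a third core.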